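The source may hold more compounds than are shown below. What is called first, only, known or untested is meant among the compounds shown, and "the series" means these compounds.

For the measured compounds named here, in an ADME assay on HEK293 cells (Homo sapiens) for cytotoxicity, with a stated time of 72 h (on this read-out higher numbers stand for an effect only at larger amounts of compound and lower numbers for an effect already at smaller amounts), only two compounds have been measured so far. Compound 1 `C=C[C@@](C)(/C=C/c1ccc(OCc2ccccc2)cc1)CCC=C(C)C` gives > 36600 nM, which is a limit of the assay and not a number. Compound 2 `C=C[C@@](C)(/C=C/c1ccc(O)c(C=O)c1)CCC=C(C)C` gives > 36600 nM, which is also a limit. Compound 2 therefore has no exact value, and the whole picture so far is the limit of > 36600 nM in this assay, at which 2 of the 2 values shown sit. Compound 3 `C=C[C@@](C)(/C=C/c1ccc(O)c(/C=C/C(=O)OCC)c1)CCC=C(C)C` differs from compound 2 in one place: 2-(ethoxycarbonyl)ethenyl in place of formyl on an aromatic carbon. Here, 2-(ethoxycarbonyl)ethenyl replaces formyl on an aromatic carbon, ortho to a hydroxy group. Going by the values given here, no measured pair shows how much a single change moves the result in this assay, so this expectation is loose. Among the compounds with values here, with the limit of > 36600 nM in this assay, at which 2 of the 2 values shown sit, as the only guide, a small step towards lower numbers is expected, or none beyond the scatter. The estimated step is an at least 1.2-fold lower number from compound 2 to compound 3 (0.08 log units; that floor lies within the scatter). For compound 3, the expected value is 30000 nM, with an estimated range from 9000 nM to 60000 nM.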

Compound 3, half-maximal effective concentration: > 36600 nM
Compound 3: no number, only a limit; the forecaster's own chance of this, stated with the estimate: 60%; middle value at least 1.2-fold (0.08 log units) away from the limit.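

No step can be read from compound 2 to compound 3, since both results are limits of the assay and not numbers. The compounds shown leave open at what concentration any of them has an effect in this assay and how much a single change moves that concentration, with this as the only guide: the limit of > 36600 nM in this assay, at which 3 of the 3 values shown sit.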